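Fluorinated butanol and pentanol series: lipophilicity notes

This account rests on a few compounds, and the source may have more. Where it says the series, first, only, none or still open, it means among the compounds named here.

Measured compounds:
compound 1 `OCCC(F)CF` — -0.12
compound 2 `OCCCCF` — 0.09

Among the measured compounds shown here, compound 1 has the lowest of the two numbers so far in a physicochemical assay for lipophilicity, read by NMR; on this read-out lower numbers stand for lower lipophilicity and higher numbers for higher lipophilicity; its nearest neighbour is compound 2, which gives 0.09, while compound 1 gives -0.12. For the measured compounds named here, the single measured step, a number 0.21 log units higher from compound 1 to compound 2 (within the scatter), removes the second fluoro of compound 1 and puts hydrogen in its place.

Compound 3 `CCC(F)CCO` is not yet measured. It differs from compound 1 by methyl in place of fluoro on a saturated chain carbon, two bonds along the chain from a fluorine atom. Going by the values given here, the change therefore removes the same fluoro as the step to compound 2, but what enters is methyl rather than hydrogen, so the measured step from compound 1 to compound 2 bears on it only in part; no measured pair in this set covers methyl entering in place of hydrogen.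

Given that the fluoro-to-hydrogen step alone read a number 0.21 log units higher from compound 1 to compound 2 (within the scatter), the expectation for compound 3 is a step upward in this assay of roughly a number 0.62 log units higher from compound 1 to compound 3 (beyond the scatter), beyond the scatter. The estimate for compound 3 is 0.5, with a range from 0.1 to 0.9.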

Compound 3, partition coefficient: 0.75
The estimate for compound 3 lay 0.25 log units below the measured number; the range from low to high includes it.
By their numbers in this assay, from the lowest: compounds 1 and 2 (each within the scatter of the next); then compound 3.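

In this assay, among the compounds shown here, methyl in place of fluoro on a saturated chain carbon, two bonds along the chain from a fluorine atom, gives the first change that clears the scatter: a number 0.87 log units higher from compound 1 to compound 3 (beyond the scatter). The earlier change, hydrogen in place of fluoro on a saturated chain carbon bound to two saturated chain carbons, stayed within it at a number 0.21 log units higher from compound 1 to compound 2 (within the scatter), so the two single changes made to compound 1 do not read alike, though they differ both in the group that enters and in where it enters. Nothing measured here explains the size of the step to compound 3 or separates the contribution of the fluoro leaving from that of the methyl entering.

Open, from the compounds shown here alone, is how hydrogen would read at the place changed in compound 3, which would show whether the step depends on the methyl entering or on the fluoro leaving. Equally open, going by these compounds, is whether a longer chain, such as propyl in place of the ethyl end of compound 3, or a polar group such as an amine at that end, would continue the same direction in this read-out.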